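Nitro for Chloro in a Whole-Organism Seizure Model

A few compounds are considered here, and "the series" means these few. Any claim that something is new, unique, unknown or untested is made for them only; others in the source may bear on it.

Three measured compounds share one core. In a functional assay on the whole organism for inhibition, with Rattus norvegicus as the target, in the maximal electroshock model, at a dose of 25 mg/kg by the intraperitoneal route (a lower number here means less inhibition, a higher number more inhibition at the dose given (going by the name of the read-out)), compound 1 `C[C@@H](c1ccccc1)n1cnc2c(N(C)C)ncnc21` gives 33%, compound 2 `CN(C)c1ncnc2c1ncn2CC1CCCCC1` gives 0%, and compound 3 `CN(C)c1ncnc2c1ncn2Cc1ccc(Cl)cc1` gives 0%. Compound 3 therefore stands level with compound 2 at the digits shown, the two together forming the lowest of the three numbers, while compound 1 lies furthest from it with a number higher by an amount beyond the usual scatter. Compound 4 `CN(C)c1ncnc2c1ncn2Cc1ccc([N+](=O)[O-])cc1` differs from compound 3 in one place: nitro in place of chloro on an aromatic carbon. Among the compounds with values here, no step between two measured compounds has been recorded, so this change is untested here. With compound 3 giving 0%, the step of a number 5 percentage points higher from compound 3 to compound 4 (within the scatter) is expected to stay within the scatter. Compound 4 is estimated at 5%, between 0% and 20%.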

Compound 4, a percentage reported as inhibition, in the whole organism at one dose (the size of the read-out at that dose, not a potency): 0%
Compound 4: middle estimate off by 5 percentage points, on the high side; the measured number falls inside the stated range.
By their numbers in this assay, from the lowest: compounds 2, 3 and 4 (each within the scatter of the next); then compound 1.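

In this assay the series gives its first direct step, no change at the digits printed from compound 3 to compound 4 (within the scatter) with nitro in place of chloro on an aromatic carbon, para to a large group. At this position, then, exchanging chloro for nitro, which brings more heavy atoms and two hydrogen-bond acceptors, leaves the read-out unmoved at the dose given. No measurement at hand offers an explanation for this result. From the compounds shown here alone, whether an amine or a carboxylic acid in this place would change the read-out stays open. So does whether compound 4 would show inhibition at another dose.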